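The source may hold more compounds than are shown below. What is called first, only, known or untested is meant among the compounds shown, and "the series" means these compounds.

Compound 1 `N=C(S)CCCCCn1nc(-c2ccccc2)ccc1=O` gives 23.3 mg/kg in a functional assay on the whole organism (stomach) with Rattus norvegicus as the target; on this read-out lower numbers stand for an effect already at smaller amounts and higher numbers for an effect only at larger amounts of compound.
Compound 3 `CC(Cn1nc(-c2ccccc2)ccc1=O)C(=N)S` gives 28.1 mg/kg in this assay.
Compound 2 `Cc1ccc(=O)n(CCCCCC(=N)S)n1` shows only a limit in this assay, > 100 mg/kg.

Among the two numbers, compound 1 stands lowest, with compound 3 nearest at a 1.2-fold higher number from compound 1 to compound 3 (0.08 log units; within the scatter). The value of compound 2 is a limit of the assay and not a number (the limit of > 100 mg/kg in this assay, at which 1 of the 3 values shown sits); it marks the step of an at least 4.2-fold higher number from compound 1 to compound 2 (0.63 log units; beyond the scatter).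

Compound 4 `C/N=C(/S)CCCCCn1nc(-c2ccccc2)ccc1=O` is not yet measured. It differs from compound 1 in one place: a group of 4 heavy atoms (2 carbon, 1 nitrogen, 1 sulfur; no ring) in place of a group of 3 heavy atoms (1 carbon, 1 nitrogen, 1 sulfur; no ring), on a saturated chain carbon, five bonds along the chain from an aromatic nitrogen. Neither measured step touches this position directly. The step from compound 1 to compound 3 changes the same saturated chain and stays within the scatter; the step from compound 1 to compound 2 changes the aromatic substituent, far from the place altered here. The closest comparison therefore points to little movement, and compound 4 is expected to land near compound 1, with a change of a 1.3-fold higher number from compound 1 to compound 4 (0.11 log units; within the scatter) that stays within the scatter. The estimate for compound 4 is 30 mg/kg, within the range 12 mg/kg to 75 mg/kg.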

Compound 4, dose for half-maximal effect: 25.2 mg/kg
Estimate against measurement, compound 4: 1.2-fold (0.08 log units) above; the measured number falls inside the stated range.
By their numbers in this assay, from the lowest: compounds 1, 4 and 3 (each within the scatter of the next). At a limit, above all of these: compound 2.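

Putting the group of 4 heavy atoms in place of the group of 3 heavy atoms, on a saturated chain carbon, five bonds along the chain from an aromatic nitrogen, gives a 1.1-fold higher number from compound 1 to compound 4 (0.03 log units; within the scatter) in this assay and so the two values stay within the scatter of each other. Among the compounds shown here, this is the first direct reading at this place, since the earlier steps changed the aromatic substituent or the chain, and it shows that this position tolerates the exchange of a group with 2 hydrogen-bond donors for one with 1 hydrogen-bond donor without a change beyond the scatter. The measurements shown give no reason for this outcome.

As far as these compounds go, whether an amine or a carboxylic acid at this place would also stay within the scatter of compound 1 remains open. So does the effect of a benzyl group or a longer chain here.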